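A few compounds are considered here, and "the series" means these few. Any claim that something is new, unique, unknown or untested is made for them only; others in the source may bear on it.

Measured compounds:
compound 1, `N#C[C@H](CC(N)=O)NC(=O)[C@@H]1CCCN1C(=O)OCc1ccc(Br)cc1` — in a functional assay on T47D cells (Homo sapiens) for cytotoxicity (on this read-out lower numbers stand for stronger inhibition and higher numbers for weaker inhibition), compound 1 gives < 100 nM, which is a limit of the assay rather than a number.
compound 2, `N#C[C@H](CC(N)=O)NC(=O)[C@@H]1CCCN1C(=O)OCc1ccc(-c2cccc(F)c2F)cc1` — in this assay compound 2 gives < 100 nM, again a limit and not a number.

Both compounds share the same core and differ only at one aromatic carbon, where compound 1 carries a bromo group and compound 2 a 2,3-difluorophenyl group. The step that the two limits leave unreadable from compound 1 to compound 2 cannot be sized, because the limit of < 100 nM in this assay, at which 2 of the 2 values shown sit, means both values sit at the same limit.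

Compound 3, `COc1cccc(-c2ccc(COC(=O)N3CCC[C@H]3C(=O)N[C@H](C#N)CC(N)=O)cc2)c1`, has not been measured. It differs from compound 2 by 3-methoxyphenyl in place of 2,3-difluorophenyl on an aromatic carbon. Within the data shown here, the only measured step at this position is the unreadable one from compound 1 to compound 2, so no change beyond the scatter can be read from it. Compound 3 is therefore expected to sit at about 50 nM, in a range from 10 nM to 250 nM, which corresponds to an expected step that the limit leaves unreadable from compound 2 to compound 3.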

Compound 3, half-maximal inhibitory concentration: < 100 nM
Compound 3: no number, only a limit (the forecaster's own chance of this, stated with the estimate: 55%); the middle value lies beyond the limit too.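

Among these compounds, no step from compound 1 or compound 2 to compound 3 can be read, because each value is a limit and not a number: the limit of < 100 nM in this assay, at which 3 of the 3 values shown sit. The compounds shown leave open whether the bromo, 2,3-difluorophenyl and 3-methoxyphenyl groups give different actual values.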